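Urea series on ovarian cancer cells: estimate for compound 4

This account rests on a few compounds, and the source may have more. Where it says the series, first, only, none or still open, it means among the compounds named here.

Measured compounds in a functional assay on A2780 cells (Homo sapiens) for inhibition, with a stated time of 72 h, tested at 10 uM; on this read-out higher numbers stand for more inhibition of growth at the one concentration tested and lower numbers for less inhibition of growth:
Compound 1, `CC1(C)CCOc2ccc(NC(=O)Nc3ccc(OC(F)(F)F)cc3)cc21`: compound 1 gives 36%.
Compound 2, `CCC1(CC)CC(CC)(CC)c2cc(NC(=O)Nc3ccc(OC(F)(F)F)cc3)ccc2O1`: compound 2 gives 67%.
Compound 3, `CCC1(CC)CC(CC)(CC)c2cc(NC(=O)Nc3ccc(C(F)(F)F)cc3)ccc2O1`: compound 3 gives 86.2%.

Compound 3 stands highest of the three, with compound 2 nearest and compound 1 furthest, both steps beyond the scatter. Compound 4, `CCC1(CC)CC(CC)(CC)c2cc(NC(=O)Nc3ccc([N+](=O)[O-])cc3)ccc2O1`, differs from compound 3 by nitro in place of trifluoromethyl on an aromatic carbon. For the measured compounds named here, no measured step carries this exchange. Going by the values given here, the only single-point step, a number 19.2 percentage points higher from compound 2 to compound 3 (beyond the scatter), concerns a different group at the same aromatic carbon and is modest; it shows that a swap of this group can move the read-out by about that much. Without a matching precedent, a drop from compound 3 of roughly that size, not a rise, is taken as the expectation. Compound 4 is expected to give 72%, range 50% to 90%, an expected step of a number 14.2 percentage points lower from compound 3 to compound 4 (beyond the scatter).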

Compound 4, percent growth inhibition at one concentration: 91.4%
Beside the measured number, compound 4's estimate is 19.4 percentage points below it; the measured number lies above the stated range.
By their numbers in this assay, from the lowest: compound 1; then compound 2; then compounds 3 and 4 (each within the scatter of the next).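

With nitro in place of trifluoromethyl on this aromatic carbon, para to a large group, this assay shows a number 5.2 percentage points higher from compound 3 to compound 4 (within the scatter) and does not separate the two groups. Nitro in place of trifluoromethoxy gives a number 24.4 percentage points higher from compound 2 to compound 4 (beyond the scatter) and so runs in the same direction as the trifluoromethyl exchange, the first sign that a second group at this carbon outperforms trifluoromethoxy on the shared core. Nothing at hand explains these steps. Open, on these data alone, is whether an amine or a carboxylic acid at this carbon would hold the read-out. Also open, as far as these compounds go, is whether nitro would give a similar step on the core of compound 1.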